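A few compounds are considered here, and "the series" means these few. Any claim that something is new, unique, unknown or untested is made for them only; others in the source may bear on it.

Measured so far:
Compound 1, `CCN1CCN(c2cc(C)c3cc(NC(=O)c4ccccc4C)ccc3n2)CC1`, gives 29200 nM in a functional assay on SK-BR-3 cells (Homo sapiens) for antiproliferative activity, read by MTT assay, with a stated time of 72 h; a lower number here means a stronger inhibitor, a higher number a weaker inhibitor.
Compound 2, `Cc1cc(N2CCCC2)nc2ccc(NC(=O)c3ccc(Cl)c(Cl)c3)cc12`, gives 43400 nM in this assay.
Compound 3, `Cc1cc(N2CCN(C(C)C)CC2)nc2ccc(NC(=O)c3ccc(Cl)c(Cl)c3)cc12`, gives 6680 nM in this assay.

Compound 1 stands second highest of the three numbers; its number sits within the usual scatter of that of compound 2 and beyond the scatter of that of compound 3, which has the lowest number shown. Compound 4, `CCN1CCN(c2cc(C)c3cc(NC(=O)c4ccc5ccccc5n4)ccc3n2)CC1`, is still unmeasured. It differs from compound 1 in one place: quinolin-2-yl in place of 2-methylphenyl on a carbonyl carbon. For the measured compounds named here, the only measured step, a 6.5-fold lower number from compound 2 to compound 3 (0.81 log units; beyond the scatter), changes the amine on an aromatic carbon of the shared core, not the group on the carbonyl carbon, so no measured step bears directly on the change from compound 1 to compound 4. Without any guide, the step of a 1.2-fold lower number from compound 1 to compound 4 (0.07 log units; within the scatter) is expected to stay within the scatter, with wide uncertainty. Compound 4 is therefore estimated at 25000 nM in this assay, between 7000 nM and 90000 nM.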

Compound 4, half-maximal inhibitory concentration: 3760 nM
Compound 4: middle estimate off by 6.6-fold (0.82 log units), on the high side, and the stated range ends above it.
By their numbers in this assay, from the lowest: compounds 4 and 3 (each within the scatter of the next); then compounds 1 and 2 (each within the scatter of the next).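

The group on the carbonyl carbon is not a silent part of these molecules: with the rest of compound 1 unchanged, a 7.8-fold lower number from compound 1 to compound 4 (0.89 log units; beyond the scatter) in this assay. For the compounds shown here, until now, the only measured step lay at the amine on the aromatic carbon, so this is the first sign that a second site on the molecule also moves the number. The change brings in several things at once, namely a second aromatic ring, a ring nitrogen and a hydrogen-bond acceptor, and nothing measured here says which of them lies behind the step.

On these data alone, it remains open whether the ring nitrogen or the second ring goes with the lower number. On the same carbonyl carbon, naphthalen-2-yl, with its carbon-only rings, and pyridin-2-yl, a single ring with one nitrogen, would begin to separate the two.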